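Propyl-for-hydrogen steps in two related cores

The source may report more compounds than this note shows. Statements on the series, on what has been measured and on what is new or still open speak of the compounds shown alone.

Measured compounds in a functional assay (brain) for displacement of a labelled ligand, with Rattus norvegicus as the target; on this read-out higher numbers stand for weaker inhibition and lower numbers for stronger inhibition:
compound 1, `C[C@]1(c2ccccc2)OC[C@H]([C@@H]2CCCCN2)O1`, 847 nM
compound 2, `CCCC[C@]1(c2ccccc2)OC[C@H]([C@@H]2CCCCN2)O1`, 200 nM
compound 3, `CCCN1CCCC[C@H]1[C@H]1COC(c2ccccc2)(c2ccccc2)O1`, 6800 nM

Compound 2 differs from compound 1 by propyl in place of hydrogen on a saturated chain carbon bound to a saturated ring carbon. Among the compounds with values here, this step, a 4.2-fold lower number from compound 1 to compound 2 (0.63 log units; beyond the scatter), is the only measured step, and it is counted as beyond the scatter. Compound 3 sits on another core; the difference between the two cores is not broken down here. In this assay compound 3 gives the highest number of the three, and its values against compound 1 and compound 2 both lie beyond the scatter.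

Compound 4, `CCCCCCN1CCCC[C@H]1[C@H]1COC(c2ccccc2)(c2ccccc2)O1`, is not yet measured. It differs from compound 3 by propyl in place of hydrogen on a saturated chain carbon, three bonds along the chain from an amine nitrogen in a ring. This is the same kind of change as that from compound 1 to compound 2, but the place differs: there the propyl enters on a saturated chain carbon bound to a saturated ring carbon, here on a saturated chain carbon three bonds along the chain from an amine nitrogen in a ring. Within the data shown here, a lowering of the number is expected, on the single measured step of a 4.2-fold lower number from compound 1 to compound 2 (0.63 log units; beyond the scatter), but with less confidence because the place is not the same; the expected step is a 2.3-fold lower number from compound 3 to compound 4 (0.36 log units; beyond the scatter). For compound 4 in this assay the estimate is 3000 nM, between 1000 nM and 9000 nM.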

Compound 4, inhibition constant: 21200 nM
The estimate for compound 4 lay 7.1-fold (0.85 log units) below the measured number, and the stated range ends below it.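

In this assay the same propyl-for-hydrogen change gives a higher number on the core of compound 3 (a 3.1-fold higher number from compound 3 to compound 4 (0.49 log units; beyond the scatter)), the opposite direction to the step on the core of compound 1. Set side by side, the two steps differ: the same change on two cores in this assay, a 4.2-fold lower number (0.63 log units; beyond the scatter) from compound 1 to compound 2 and a 3.1-fold higher number (0.49 log units; beyond the scatter) from compound 3 to compound 4, 13-fold (1.12 log units) apart, beyond the scatter of two such steps. The lowering seen on the core of compound 1 therefore cannot be assumed to carry over to the core of compound 3, but this does not show whether the core or the place of the propyl sets the direction: the two differ together, and each core offers a single step, which gives no general rule.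

Open, going by these compounds, is how the number runs along the chain on the core of compound 3, for example with a butyl or a longer chain such as octyl. Also open, on these data alone, is whether a terminal amine or carboxylic acid on that chain would give a different result.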